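Amino to acetamido, starting from a limit

The source may hold more compounds than are shown below. What is called first, only, known or untested is meant among the compounds shown, and "the series" means these compounds.

In a functional assay on cells (Homo sapiens) for inhibition, read by MTT assay, with a stated time of 72 h (on this read-out lower numbers stand for stronger inhibition and higher numbers for weaker inhibition), compound 1 (`CC(=O)Nc1ccc(Nc2ncnc3c2cnn3CC(=O)O)cc1`) gives > 64 ug/mL, which is a limit of the assay. Compound 2 (`CCOC(=O)Cn1ncc2c(Nc3ccc(N)cc3)ncnc21`) gives > 64 ug/mL, also a limit, so no number places it. Both values sit at the same limit: the limit of > 64 ug/mL in this assay, at which 2 of the 2 values shown sit. Compound 3 (`CCOC(=O)Cn1ncc2c(Nc3ccc(NC(C)=O)cc3)ncnc21`) has acetyl in place of hydrogen on a nitrogen on an aromatic ring. No measured step sizes this change in this assay, and no change beyond the scatter is expected. The estimated step is a number no higher from compound 2 to compound 3 (the limit leaves the size open). For compound 3 the estimated value is 64 ug/mL, with an expected range of 32 ug/mL to 128 ug/mL.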

Compound 3, half-maximal inhibitory concentration: > 64 ug/mL
Compound 3 ended at the assay's limit (the forecaster's own chance of this, stated with the estimate: 75%); the middle value lies on the limit itself.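

Compound 3 stands at a limit, as do compound 1 and compound 2, so neither step to compound 3 can be read: the limit of > 64 ug/mL in this assay, at which 3 of the 3 values shown sit.

The compounds shown leave open whether acetyl or ethyl in place of hydrogen changes the result at all in this assay.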